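A few compounds are considered here, and "the series" means these few. Any claim that something is new, unique, unknown or untested is made for them only; others in the source may bear on it.

Compound 1 `COc1ccc(C(=O)O[C@H]2C=C(C)C(=O)C[C@@]3(C)CC[C@@](O)(C(C)C)[C@H]23)cc1` and compound 2 `CC1=C[C@H](OC(=O)c2ccc(O)cc2)[C@@H]2[C@](C)(CC[C@@]2(O)C(C)C)CC1=O` share one core and differ by a single change, (hydrogen in place of methyl on an oxygen on an aromatic ring). In a functional assay on A549 cells (Homo sapiens) for cytotoxicity, read by MTT assay, with a stated time of 72 h (a higher number here means a weaker inhibitor, a lower number a stronger inhibitor), compound 1 gives 31800 nM, and in this assay compound 2 gives 14500 nM; this amounts to a 2.2-fold lower number from compound 1 to compound 2 (0.34 log units; beyond the scatter). Compound 3 `COc1ccc(C(=O)O[C@H]2CC(C)=CC[C@@]3(C)CC[C@@](O)(C(C)C)[C@H]23)cc1` has a different core; how the two cores differ is not broken down here. In this assay compound 3 gives 31900 nM, which sits within the scatter of compound 1. Compound 4 `CC1=CC[C@@]2(C)CC[C@@](O)(C(C)C)[C@@H]2[C@@H](OC(=O)c2ccc(O)cc2)C1` is made from compound 3 by the same change, (hydrogen in place of methyl on an oxygen on an aromatic ring), and the place where it happens reads the same as before. Because compound 2 showed a 2.2-fold lower number from compound 1 to compound 2 (0.34 log units; beyond the scatter), the step to compound 4 is expected to be about as large, a 2.1-fold lower number from compound 3 to compound 4 (0.33 log units; beyond the scatter). Compound 4 is thus estimated at 15000 nM, with a likely range from 7000 nM to 35000 nM.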

Compound 4, half-maximal inhibitory concentration: > 100000 nM
Compound 4 ended at the assay's limit; the forecaster's own chance of this, stated with the estimate: 5%; middle value at least 6.6-fold (0.82 log units) from the limit.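

Going from 4-methoxyphenyl to 4-hydroxyphenyl on the second core gives an at least 3.1-fold higher number from compound 3 to compound 4 (0.49 log units; beyond the scatter) in this assay, which runs opposite to the step on the first core, and the two steps do not match: the same change on two cores in this assay, a 2.2-fold lower number (0.34 log units; beyond the scatter) from compound 1 to compound 2 and an at least 3.1-fold higher number (0.49 log units; beyond the scatter) from compound 3 to compound 4, at least 6.8-fold (0.83 log units) apart, beyond the scatter of two such steps. Compound 4 gives > 100000 nM, which is a limit of the assay and not a number. In these two pairs, then, the change did not carry over from one core to the other, but the result does not show which difference between the cores is responsible, or how large the second step really is.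

The compounds shown leave open how an amine or a carboxylic acid in place of the hydroxy group would behave on each core. They also leave open whether a longer chain on the oxygen, such as ethoxy, would split the two cores in the same way.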